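Replacing 4-fluorophenyl with 2,4-dichlorophenyl

This account rests on a few compounds, and the source may have more. Where it says the series, first, only, none or still open, it means among the compounds named here.

Going by the values given here, in a functional assay on A549 cells (Homo sapiens) for cytotoxicity, read by MTT assay, with a stated time of 72 h (on this read-out higher numbers stand for weaker inhibition and lower numbers for stronger inhibition), compound 3 `CNC(=O)c1cc(Oc2ccc(C(=O)/C=C/c3ccc(F)cc3)cc2)ccn1` gives 18600 nM as the only actual number so far. Compound 2 `CNC(=O)c1cc(Oc2ccc(C(=O)/C=C/c3ccc([N+](=O)[O-])cc3)cc2)ccn1` gives > 50000 nM as its entry, and that is a limit and not a number. Compound 1 `CNC(=O)c1cc(Oc2ccc(C(=O)/C=C/c3ccco3)cc2)ccn1` carries the entry "not determined" (no result reported) and so offers nothing to compare.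

Compound 4 `CNC(=O)c1cc(Oc2ccc(C(=O)/C=C/c3ccc(Cl)cc3Cl)cc2)ccn1` keeps the core of compound 3 and swaps one group: 2,4-dichlorophenyl in place of 4-fluorophenyl on a double-bonded chain carbon bound to a double-bonded chain carbon. The count of what changes is 2,4-dichlorophenyl in place of 4-fluorophenyl on a double-bonded chain carbon bound to a double-bonded chain carbon and the rest of the structure stays the same.

Among the compounds with values here, the only measured step that bears on this swap is an at least 2.6-fold lower number from compound 2 to compound 3 (0.42 log units; beyond the scatter) and it lies beyond the scatter. It shows that changing a group on this aromatic ring can move the number, but it involves no chlorine and says little about size here. The expected step is a 1.6-fold lower number from compound 3 to compound 4 (0.19 log units; within the scatter) and this estimate stays within the scatter. For compound 4 the estimated value is 12000 nM with an expected range from 4000 nM to 40000 nM on this read-out.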

Compound 4, half-maximal inhibitory concentration: 9460 nM
Beside the measured number, compound 4's estimate is 1.3-fold (0.10 log units) above it; low and high end bracket the measured number.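

In this assay, the move to two chlorines gives a 2.0-fold lower number from compound 3 to compound 4 (0.29 log units; within the scatter), so the two compounds cannot be told apart on this read-out, and a larger ring with two halogen atoms at this position brings no measurable loss compared with 4-fluorophenyl. The comparison with the nitro compound gives an at least 5.2-fold lower number from compound 2 to compound 4 (0.72 log units; beyond the scatter), so 2,4-dichlorophenyl, like 4-fluorophenyl, gives a lower number than 4-nitrophenyl by more than the scatter. The entry for compound 2 is a limit and not a number, so this step gives only a minimum size: the limit of > 50000 nM in this assay, at which 1 of the 4 values shown sits.

The compounds shown cannot separate the contributions of the two chlorines, since no ring here carries a single chlorine, and one chlorine might account for all, part or none of the small difference seen. From the compounds shown here alone, it also remains open how this position would respond to a ring bearing an amine, a carboxylic acid or a methoxy group, or whether any change here could lower the number well beyond the scatter from that of compound 4.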